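Cytotoxicity notes on a fluorobenzyl-substituted indole diketo series

A few compounds are considered here, and "the series" means these few. Any claim that something is new, unique, unknown or untested is made for them only; others in the source may bear on it.

Measured so far:
- compound 1, `CCOC(=O)/C(O)=C/C(=O)c1cn(Cc2cc(F)c(F)c(F)c2)c2cccc(OC)c12`, 33400 nM in an ADME assay on MT4 cells (Homo sapiens) for cytotoxicity, read by MTT assay; on this read-out lower numbers stand for higher toxicity in this test and higher numbers for lower toxicity in this test
- compound 2, `COc1cccc2c1c(C(=O)/C=C(\O)C(=O)O)cn2Cc1cc(F)ccc1F`, 46200 nM in this assay

Compound 2 carries the highest of the two numbers in this assay; its nearest neighbour is compound 1, whose number is lower, but the gap between the two lies within the usual scatter of this measurement, so no order between them can be read from it.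

The next step goes from compound 2 to compound 3, `COc1cccc2c1c(C(=O)/C=C(\O)C(=O)O)cn2Cc1ccccc1F`. The change is hydrogen in place of fluoro on an aromatic carbon of the benzyl group, which turns a 2,5-difluorobenzyl into a 2-fluorobenzyl. For the measured compounds named here, no pair of measured compounds that differ in exactly this way is available, so the size of the step has to be guessed. Both measured numbers sit close together, and a single fluorine removed from the benzyl ring is a small change; the expectation is therefore no step beyond the scatter in either direction.

For compound 3 in this assay the estimate is 45000 nM, with a range from 20000 nM to 100000 nM. This estimated step from compound 2 to compound 3 is a 1.0-fold lower number from compound 2 to compound 3 (0.01 log units; within the scatter).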

Compound 3, half-maximal cytotoxic concentration: 70500 nM
Compound 3: middle estimate off by 1.6-fold (0.19 log units), on the low side; measured number inside the range.
By their numbers in this assay, from the lowest: compounds 1, 2 and 3 (each within the scatter of the next, the first and the last beyond it).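

For the compounds shown here, the first step between compounds that differ in one place reads, in this assay, as a 1.5-fold higher number from compound 2 to compound 3 (0.18 log units; within the scatter), for hydrogen in place of fluoro on the aromatic carbon meta to a large group and para to a fluoro group. At this carbon of the benzyl group, the 2,5-difluorobenzyl and 2-fluorobenzyl forms therefore cannot be told apart in this read-out, which means that this fluoro group can be exchanged for hydrogen without a shift that clears the scatter. No available evidence bears on this result.

Still open is whether a larger group at the same carbon, such as a chloro, a methoxy or an amine, would give a step beyond the scatter, since fluoro and hydrogen are the only two substituents shown there. Also open, as far as these compounds go, is what happens when the remaining fluoro group of the 2-fluorobenzyl is exchanged for hydrogen, leaving a plain benzyl on the shared core.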